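The source may hold more compounds than are shown below. What is called first, only, known or untested is meant among the compounds shown, and "the series" means these compounds.

Measured so far in a functional assay on MCF7 cells (Homo sapiens) for inhibition, with a stated time of 96 h; a lower number here means a stronger inhibitor, a higher number a weaker inhibitor:
compound 1 `COc1cc(C(=O)c2cn(-c3cccc(C)c3)cc2-c2ccsc2)cc(OC)c1OC`: 65 nM
compound 2 `COc1cc(C(=O)c2cn(-c3ccc(C)cc3)cc2-c2nccs2)cc(OC)c1OC`: 14 nM
compound 3 `COc1cc(C(=O)c2cn(-c3ccc(F)cc3)cc2-c2ccsc2)cc(OC)c1OC`: 15 nM

Compound 3 and compound 2 lie within the usual scatter of each other in this assay, while compound 1 stands apart from compound 3. Going by the values given here, that gap is the one measured step available, a 4.3-fold lower number from compound 1 to compound 3 (0.64 log units; beyond the scatter), and it is modest.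

The next compound is compound 4 `COc1cc(C(=O)c2cn(-c3ccc(F)cc3)cc2-c2nccs2)cc(OC)c1OC`. It keeps the 4-fluorophenyl group of compound 3 but has 1,3-thiazol-2-yl in place of thiophen-3-yl on an aromatic carbon. Among the compounds with values here, the measured step changes the group on the aromatic nitrogen, not this place, so it gives no direct guide, and no measured pair shows this swap alone. The nearest evidence is compound 2, which carries the same 1,3-thiazol-2-yl group with 4-methylphenyl on the nitrogen and gives 14 nM. A large change therefore seems unlikely. The expected step, no change at the digits printed from compound 3 to compound 4 (within the scatter), is none beyond the scatter. The estimate for compound 4 is 15 nM, with an expected range of 6 nM to 40 nM.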

Compound 4, half-maximal inhibitory concentration: 22 nM
The estimate for compound 4 lay 1.5-fold (0.17 log units) below the measured number; the measured number falls inside the stated range.
By their numbers in this assay, from the lowest: compounds 2, 3 and 4 (each within the scatter of the next); then compound 1.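

In this assay, this swap on an aromatic carbon of the five-membered aromatic ring can now be read directly: it gives a 1.5-fold higher number from compound 3 to compound 4 (0.17 log units; within the scatter) and so does not tell 1,3-thiazol-2-yl from thiophen-3-yl, although the entering ring has a second hetero atom, a nitrogen. With 1,3-thiazol-2-yl held in place, the para-free comparison of the group on the ring nitrogen gives a 1.6-fold higher number from compound 2 to compound 4 (0.20 log units; within the scatter) and so does not separate fluoro from methyl on that phenyl ring either. No independent measurement is available to explain either result.

At this position the compounds shown hold only these two five-membered aromatic rings, so the effect of a plain phenyl ring or an amine there remains open. Also open, going by these compounds, is whether 3-methylphenyl on the ring nitrogen would give a similar step when paired with 1,3-thiazol-2-yl.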